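A few compounds are considered here, and "the series" means these few. Any claim that something is new, unique, unknown or untested is made for them only; others in the source may bear on it.

Compound 1 `O=S(=O)(/C=C/c1ccc(Cl)c(Cl)c1)Cc1ccc(Nc2ncnc3ccccc23)cc1`: 28000 nM
Compound 2 `CC(C)(C)c1cc(/C=C/S(=O)(=O)Cc2ccc(Nc3ncnc4ccccc34)cc2)cc(C(C)(C)C)c1O`: > 100000 nM (a limit of the assay)

Among the measured compounds shown here, in a functional assay on ACHN cells (Homo sapiens) (a higher number here means a weaker inhibitor of growth, a lower number a stronger inhibitor of growth), compound 1 gives 28000 nM as the only true number so far. Compound 2 reads > 100000 nM and this is a limit, not a number. That leaves compound 1 as the sole measured reference point.

Compound 3 `O=S(=O)(/C=C/c1ccc(F)cc1F)Cc1ccc(Nc2ncnc3ccccc23)cc1` keeps the core of compound 1 and places 2,4-difluorophenyl in place of 3,4-dichlorophenyl on a double-bonded chain carbon bound to a double-bonded chain carbon. For the measured compounds named here, no measured pair shows what such a swap does, so in this assay no step beyond the usual scatter is expected, and no direction can be favoured. The expectation therefore stays close to compound 1 at 28000 nM and carries a wide margin. The estimated move is a 1.1-fold higher number from compound 1 to compound 3 (0.03 log units; within the scatter). For compound 3 the expected value is 30000 nM, with an estimated range from 10000 nM to 90000 nM.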

Compound 3, concentration for 50% growth inhibition: 31000 nM
Estimate against measurement, compound 3: 1.0-fold (0.01 log units) below, within the range that was stated.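

In this assay, among the compounds shown here, putting 2,4-difluorophenyl in place of 3,4-dichlorophenyl on the double-bonded chain carbon gives the first step that can be read at this position (a 1.1-fold higher number from compound 1 to compound 3 (0.04 log units; within the scatter)). Compound 1 and compound 3 cannot be told apart here, so this particular exchange of one disubstituted phenyl for another leaves growth inhibition unchanged within the scatter. Both the halogen and its ring positions differ in this single step, so it cannot show what either change does alone.

Still open, as far as these compounds go, is whether a phenyl ring carrying an amine or a carboxylic acid at this position would give a step beyond the scatter. Compound 2 adds no readable step, as its value is a limit and not a number: the limit of > 100000 nM in this assay, at which 1 of the 3 values shown sits.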